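Working notes on solubility across four piperazine amides

This account rests on a few compounds, and the source may have more. Where it says the series, first, only, none or still open, it means among the compounds named here.

Measured so far in a physicochemical assay for solubility, read by HPLC; on this read-out lower numbers stand for lower solubility and higher numbers for higher solubility:
- compound 1, `O=C(C1CC1)N1CCN(c2nc(=O)c3cc(C(F)(F)F)cc([N+](=O)[O-])c3s2)CC1`: 52.9 ug/mL
- compound 2, `O=c1nc(N2CCN(CC3CCCCC3)CC2)sc2c([N+](=O)[O-])cc(C(F)(F)F)cc12`: 9.07 ug/mL
- compound 3, `CCCC(=O)N1CCN(c2nc(=O)c3cc(C(F)(F)F)cc([N+](=O)[O-])c3s2)CC1`: 2.46 ug/mL

Compound 3 stands lowest of the three numbers. Its nearest neighbour is compound 2, with a 3.7-fold lower number from compound 2 to compound 3 (0.57 log units; beyond the scatter); the furthest is compound 1, with a 22-fold lower number from compound 1 to compound 3 (1.33 log units; beyond the scatter). The remaining measured step, a 5.8-fold lower number from compound 1 to compound 2 (0.77 log units; beyond the scatter), connects the two higher values.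

The next compound, compound 4, `CCCCC(=O)N1CCN(c2nc(=O)c3cc(C(F)(F)F)cc([N+](=O)[O-])c3s2)CC1`, differs from compound 3 in one place: methyl in place of hydrogen on a saturated chain carbon, three bonds along the chain from a carbonyl carbon. Within the data shown here, none of the measured steps alters a saturated chain in this way; the closest in kind is the change from compound 1 to compound 3, where a propyl replaced a cyclopropyl on the carbonyl carbon and the number fell by a large margin. Lengthening the same chain by one carbon is a smaller change than that, so a step in this assay downward from compound 3 to compound 4 is expected, but of a size near the edge of the usual scatter rather than clearly beyond it.

Compound 4 is therefore estimated at 1.5 ug/mL, with a range from 0.5 ug/mL to 4 ug/mL. The expected step is a 1.6-fold lower number from compound 3 to compound 4 (0.21 log units; within the scatter).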

Compound 4, solubility: 42.5 ug/mL
Compound 4: the middle estimate sits 28-fold (1.45 log units) below what was measured; the whole stated range lies below it.
By their numbers in this assay, from the lowest: compound 3; then compound 2; then compounds 4 and 1 (each within the scatter of the next).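

In this assay methyl in place of hydrogen on a saturated chain carbon, three bonds along the chain from a carbonyl carbon, gives a 17-fold higher number from compound 3 to compound 4 (1.24 log units; beyond the scatter) and so shows that this position can carry a large upward step from a single added carbon. The other two comparisons read a 4.7-fold higher number from compound 2 to compound 4 (0.67 log units; beyond the scatter) and a 1.2-fold lower number from compound 1 to compound 4 (0.10 log units; within the scatter) and leave compound 3 as the one low amide of the three, so the number does not follow the length of the group on the carbonyl carbon across these compounds. Nothing in hand accounts for this sharp rise on going from the propyl to the butyl chain.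

The compounds shown leave open whether the low number belongs to the propyl chain alone, and whether an ethyl chain or a longer chain such as pentyl would sit with compound 3 or with compound 4. They also leave open whether an amine or a carboxylic acid on the butyl chain would hold the number near that of compound 4.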